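Adding hydroxy to the phenyl of compound 3

This account rests on a few compounds, and the source may have more. Where it says the series, first, only, none or still open, it means among the compounds named here.

Measured in a functional assay on SGC-7901 cells (Homo sapiens) for inhibition, read by MTT assay, with a stated time of 24 h; on this read-out higher numbers stand for weaker inhibition and lower numbers for stronger inhibition:
- compound 1 `CC1(C)[C@H]2CC[C@]1(C)N(Cc1cn(-c3ccccc3Br)nn1)C(=O)C2` gives 500 nM
- compound 2 `COc1ccccc1-n1cc(CN2C(=O)C[C@@H]3CC[C@@]2(C)C3(C)C)nn1` gives 280 nM
- compound 3 `CC1(C)[C@H]2CC[C@]1(C)N(Cc1cn(-c3ccccc3)nn1)C(=O)C2` gives 240 nM

Compound 3 stands at 240 nM and is the unsubstituted phenyl member of this small set. It lies within the scatter of compound 2 and clear of compound 1 by a modest margin.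

The next compound is compound 4 `CC1(C)[C@H]2CC[C@]1(C)N(Cc1cn(-c3cccc(O)c3)nn1)C(=O)C2` and the change is hydroxy in place of hydrogen on an aromatic carbon in the form of hydroxy in place of hydrogen on an aromatic carbon, meta to a large group. For the measured compounds named here, no measured compound carries hydroxy or tests that place on the ring, so the evidence is indirect.

Going by the values given here, two measured steps bear on it, and both concern removing a group from the same aromatic ring. Replacing bromo with hydrogen gives a 2.1-fold lower number from compound 1 to compound 3 (0.32 log units; beyond the scatter) and is modest. Replacing methoxy with hydrogen gives a 1.2-fold lower number from compound 2 to compound 3 (0.07 log units; within the scatter) and stays within the scatter.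

Neither substituted compound lies beyond the scatter on the lower side of compound 3, so a small rise or no real change is expected. The expected result is a 1.3-fold higher number from compound 3 to compound 4 (0.10 log units; within the scatter) and this stays within the scatter. In this assay compound 4 is estimated at 300 nM and expected to fall between 130 nM and 700 nM in most repeat measurements.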

Compound 4, half-maximal inhibitory concentration: 270 nM
Estimate against measurement, compound 4: 1.1-fold (0.05 log units) above; the measured number falls inside the stated range.
By their numbers in this assay, from the lowest: compounds 3, 4, 2 and 1 (each within the scatter of the next, the first and the last beyond it).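

In this assay, hydroxy on the aromatic carbon meta to a large group leaves the number within the scatter of the unsubstituted phenyl member (a 1.1-fold higher number from compound 3 to compound 4 (0.05 log units; within the scatter)), so this place accepts a hydroxy with no readable shift. The same holds against the 2-methoxyphenyl member (a 1.0-fold lower number from compound 2 to compound 4 (0.02 log units; within the scatter)) and, more notably, against the 2-bromophenyl member (a 1.9-fold lower number from compound 1 to compound 4 (0.27 log units; within the scatter)), whereas the unsubstituted phenyl member stands just clear of that bromo compound (a 2.1-fold lower number from compound 1 to compound 3 (0.32 log units; beyond the scatter)); compound 4 therefore lies within the scatter of all three earlier compounds and does not sharpen the small spread among them. Nothing available gives a reason for this flat result.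

For the compounds shown here, the set holds only one group at this place and no hydroxy on any other carbon of the ring, so it remains open whether the flat response belongs to this place or to hydroxy alone. An amine, a carboxylic acid or a longer chain such as butoxy at the same carbon would show whether this place stays as permissive with larger or charged-capable groups.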